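This account rests on a few compounds, and the source may have more. Where it says the series, first, only, none or still open, it means among the compounds named here.

Working notes on the series. Compound 1 `Cc1nc2c(/C=C/c3ccccc3)cccn2c1C` and compound 2 `Cc1nc2c(/C=C/c3ccccc3)cccn2c1N` share one core; compound 3 `Cc1nc2c(/C=C\Cc3ccccc3)cccn2c1C` and the unmeasured compound 4 `Cc1nc2c(/C=C\Cc3ccccc3)cccn2c1N` share another, and the difference between the two cores is not broken down here. In a functional assay on the whole organism for inhibition, with Rattus norvegicus as the target, with a stated time of 1 h (a higher number here means that more compound is needed for the effect, a lower number that less compound is needed), compound 1 gives 10.4 mg/kg and compound 2 gives 13 mg/kg. The change from compound 1 to compound 2 is amino in place of methyl on an aromatic carbon, and it made a 1.3-fold higher number from compound 1 to compound 2 (0.10 log units; within the scatter). In this assay compound 3 gives 6.6 mg/kg, a figure within the scatter of both compound 1 and compound 2, so no ordering among the three is claimed. The change from compound 3 to compound 4 is amino in place of methyl on an aromatic carbon, the same change carried onto the second core. For the measured compounds named here, for compound 4 in this assay the expected step is a 1.3-fold higher number from compound 3 to compound 4 (0.11 log units; within the scatter), resting on the one earlier instance of this change, measured as a 1.3-fold higher number from compound 1 to compound 2 (0.10 log units; within the scatter), a step within the scatter. Compound 4 is accordingly estimated at 8.5 mg/kg, with a likely range from 4.5 mg/kg to 16 mg/kg, because compound 3 gives 6.6 mg/kg and the change has so far moved the number only slightly. The measured value for compound 4 follows.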

Compound 4, dose for half-maximal effect: 8.6 mg/kg
Beside the measured number, compound 4's estimate is 1.0-fold (0.01 log units) below it; the measured number falls inside the stated range.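

In this assay, amino in place of methyl on an aromatic carbon gave a 1.3-fold higher number from compound 3 to compound 4 (0.11 log units; within the scatter), and the two instances of this change compare as follows: the same change on two cores in this assay, a 1.3-fold higher number (0.10 log units; within the scatter) from compound 1 to compound 2 and a 1.3-fold higher number (0.11 log units; within the scatter) from compound 3 to compound 4, 1.0-fold (0.02 log units) apart, within the scatter of two such steps. On these two cores, the step therefore carries over with no difference that can be told from the scatter, and the difference between the cores leaves no mark on it. This does not show that the change itself moves the number, since each step is within the scatter, and two cores in a single assay cannot establish that the same would hold on any other core in the series.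

The compounds shown carry only methyl or amino at this place, so it remains open whether a carboxylic acid, a hydroxyl group or a longer alkyl chain there would give a step beyond the scatter. Going by these compounds, it also remains open whether such a step would then carry from the core of compound 1 to the core of compound 3.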